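This account rests on a few compounds, and the source may have more. Where it says the series, first, only, none or still open, it means among the compounds named here.

Measured so far, growth inhibition read in a functional assay on U-251 cells (Homo sapiens) for inhibition, read by sulforhodamine B assay, with a stated time of 48 h; on this read-out lower numbers stand for stronger inhibition of growth and higher numbers for weaker inhibition of growth:

- compound 1 `CCOC(=O)C1=C(C)NC(=S)NC1c1ccc(O)c(O)c1`: 26.5 ug/mL
- compound 2 `CCOC(=O)C1=C(C)NC(=S)NC1c1cc(OC)c(O)c(OC)c1`: 0.77 ug/mL
- compound 3 `CCOC(=O)C1=C(C)NC(=O)NC1c1ccc(O)c(O)c1`: 0.25 ug/mL

Compound 3 gives the lowest number of the three in this assay. Its nearest neighbour is compound 2, which sits somewhat higher, a gap beyond the scatter; compound 1 lies far higher again. Compound 1 and compound 3 share the same aryl group and differ only in the thiocarbonyl against the carbonyl in the core, so the catechol-bearing urea is the reference point of the set.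

Compound 4 `CCOC(=O)C1=C(C)NC(=O)NC1c1ccc(O)cc1` has not yet been run in this assay. Relative to compound 3 the change is hydrogen in place of hydroxy on an aromatic carbon. Going by the values given here, no measured pair shows what removing one hydroxy from this aryl ring does, so the step has to be guessed. The remaining compounds give no anchor: compound 2 carries a different aryl substitution and compound 1 a different core. The expectation is a moderate rise in the number, likely beyond the scatter but well short of the gap from compound 3 to compound 1. For compound 4 the expected step from the reference is a 4.8-fold higher number from compound 3 to compound 4 (0.68 log units; beyond the scatter). Compound 4 is thus estimated at 1.2 ug/mL, in a range from 0.3 ug/mL to 6 ug/mL.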

Compound 4, concentration for 50% growth inhibition: 4.2 ug/mL
Compound 4: the middle estimate sits 3.5-fold (0.54 log units) below what was measured; measured number inside the range.
By their numbers in this assay, from the lowest: compound 3; then compound 2; then compound 4; then compound 1.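

In this assay, hydrogen in place of hydroxy on this aromatic carbon, ortho to a hydroxy group and meta to a large group, gives a 17-fold higher number from compound 3 to compound 4 (1.23 log units; beyond the scatter), a large step beyond the scatter. Going by these compounds alone, this is the first change confined to the aryl ring, with the core and all other groups held constant, and it shows that growth inhibition depends strongly on the aryl substitution as well as on the core. A single hydroxy at this position accounts for much of the low number of compound 3, while compound 4, which keeps its other hydroxy, still gives a measurable value of 4.2 ug/mL, but nothing at hand explains the size of the step.

Whether a methoxy group, an amine or a fluorine on this carbon would hold the number near that of compound 3 remains open, so the compounds shown do not separate a need for hydroxy itself from a need for any substituent here. Also open, going by these compounds, are what the remaining hydroxy contributes and whether the same change on the core of compound 1 would give a step of similar size.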